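This account rests on a few compounds, and the source may have more. Where it says the series, first, only, none or still open, it means among the compounds named here.

Compound 1, `CC1(C)Cc2c(OCc3ccccc3)ccc(C(=O)/C=C/c3cn(-c4ccccc4)nc3-c3ccc([N+](=O)[O-])cc3)c2O1`, is measured in a functional assay on B16 cells (Mus musculus) for antiproliferative activity, read by MTT assay, with a stated time of 48 h; a higher number here means a weaker inhibitor, a lower number a stronger inhibitor. In this assay compound 1 gives only a limit, > 100000 nM, and no number. Compound 2, `CC1(C)Cc2c(ccc(C(=O)/C=C/c3ccc(Cl)cc3Cl)c2OCc2ccccc2)O1`, also reaches only a limit in this assay, > 100000 nM. Compound 3, `CC1(C)Cc2c(OCc3ccccc3)ccc(C(=O)/C=C/c3ccc(F)cc3)c2O1`, likewise stands at a limit, > 100000 nM. The three measured values therefore share one feature: the limit of > 100000 nM in this assay, at which 3 of the 3 values shown sit. For the measured compounds named here, no step between two measured compounds is available, so compound 1 can only be placed at that limit, alongside compound 2 and compound 3, and not ordered against them.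

Compound 4, `Cc1ccc(-c2nn(-c3ccccc3)cc2/C=C/C(=O)c2ccc(OCc3ccccc3)c3c2OC(C)(C)C3)cc1`, has not yet been measured. It differs from compound 1 in one place: methyl in place of nitro on an aromatic carbon. Going by the values given here, with all three measured compounds at the limit, there is no measured step on which to base a direction for this change. The step that the limit leaves unreadable from compound 1 to compound 4 is expected to show no change beyond the scatter. For compound 4 the estimate in this assay is 150000 nM, expected to fall between 50000 nM and 500000 nM, most likely again reported only as a limit.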

Compound 4, half-maximal inhibitory concentration: > 100000 nM
Compound 4 gave a limit, no number; the forecaster's own chance of this, stated with the estimate: 85%; the middle value is on the limit's open side.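

In this assay compound 4 gives > 100000 nM, a limit and not a number. For the compounds shown here, compound 1 stands at a limit too, so no step from it to compound 4 can be read. The compounds shown leave open whether methyl and nitro differ at all in this assay, and what any of these compounds' actual values would be.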